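The compounds below may be only part of what the source reports. "The series", "measured", "known", "first", "only" and "open" are said of these compounds alone.

The measured compounds so far:
compound 1 `O=S(=O)(NCCNCc1cccc2ccccc12)c1cc(C(F)(F)F)cc(C(F)(F)F)c1`, with 24000 nM in a functional assay on PANC-1 cells (Homo sapiens) for inhibition, read by MTT assay, with a stated time of 72 h; a higher number here means a weaker inhibitor of growth, a lower number a stronger inhibitor of growth;
compound 2 `O=S(=O)(NCCCNCC1COc2ccccc2O1)c1cc(C(F)(F)F)cc(C(F)(F)F)c1`, with 3400 nM in this assay;
compound 3 `CN(CCCNS(=O)(=O)c1cc(C(F)(F)F)cc(C(F)(F)F)c1)Cc1ccccc1`, for which this assay reports only a limit, > 50000 nM.

Compound 2 gives the lowest of the two numbers, with compound 1 a step higher that lies beyond the scatter. Compound 3 sits at the limit of > 50000 nM in this assay, at which 1 of the 3 values shown sits, a limit rather than a number. Compound 4 `O=S(=O)(NCCCNCc1ccc(Cl)cc1)c1cc(C(F)(F)F)cc(C(F)(F)F)c1` differs from compound 2 in one place: 4-chlorophenyl in place of 2,3-dihydro-1,4-benzodioxin-2-yl on a saturated chain carbon bound to an amine nitrogen. Within the data shown here, no pair of measured compounds isolates this change, so the expectation rests on compound 2 alone. The step expected in this assay is a 1.8-fold higher number from compound 2 to compound 4 (0.25 log units; within the scatter), modestly upward or none beyond the scatter. Compound 4 is therefore estimated at 6000 nM, within 2000 nM to 20000 nM.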

Compound 4, concentration for 50% growth inhibition: 4900 nM
Compound 4: middle estimate off by 1.2-fold (0.09 log units), on the high side; measured number inside the range.
By their numbers in this assay, from the lowest: compounds 2 and 4 (each within the scatter of the next); then compound 1. At a limit, above all of these: compound 3.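

In this assay, the change to 4-chlorophenyl gives a 1.4-fold higher number from compound 2 to compound 4 (0.16 log units; within the scatter), so the non-aromatic ring with its hetero atoms can be replaced at this place without a loss beyond the scatter. The second change, (4-chlorobenzyl)amino in place of benzyl(methyl)amino, gives an at least 10-fold lower number from compound 3 to compound 4 (1.00 log units; beyond the scatter). That step starts from a limit rather than a number: the limit of > 50000 nM in this assay, at which 1 of the 4 values shown sits.

These steps do not separate the methyl on the amine from the chlorine. From the compounds shown here alone, how a plain benzylamino group would read, or a methoxy group in place of the chlorine, remains open.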